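Working notes: the fluoro step from compound 1 to compound 4

A few compounds are considered here, and "the series" means these few. Any claim that something is new, unique, unknown or untested is made for them only; others in the source may bear on it.

Measured in a functional assay on J774 cells (Mus musculus) for cytotoxicity, read by resazurin assay, with a stated time of 72 h; on this read-out higher numbers stand for weaker inhibition and lower numbers for stronger inhibition:
Compound 1, `O=S(=O)(Nc1cccc(CO)c1)c1ccc(-c2ccccc2)cc1`: 2200 nM
Compound 2, `CN(c1cccc(CO)c1)S(=O)(=O)c1ccc(-c2ccc(Cl)cc2Cl)cc1`: 2200 nM
Compound 3, `O=C(Nc1cccc(CO)c1)c1ccc(-c2ccccc2)cc1`: a limit, > 15000 nM

Compound 1 stands level with compound 2 at the digits shown, within the scatter; no order is drawn between the two. Among the compounds with values here, compound 3 sits at a limit and gives no number, see (the limit of > 15000 nM in this assay, at which 1 of the 3 values shown sits); no step between it and compound 1 is counted.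

Compound 4, `O=S(=O)(Nc1cccc(CO)c1)c1ccc(-c2ccc(F)cc2)cc1`, is not yet measured. It differs from compound 1 by fluoro in place of hydrogen on an aromatic carbon. Within the data shown here, no counted step touches this change, so the expectation rests on compound 1 alone. The step from compound 1 to compound 4 is expected to be small, a 1.1-fold lower number from compound 1 to compound 4 (0.04 log units; within the scatter), with no direction beyond the scatter. Compound 4 is estimated at 2000 nM, between 800 nM and 5000 nM.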

Compound 4, half-maximal inhibitory concentration: 3500 nM
The estimate for compound 4 lay 1.8-fold (0.24 log units) below the measured number; measured number inside the range.
By their numbers in this assay, from the lowest: compounds 1, 2 and 4 (each within the scatter of the next). At a limit, above all of these: compound 3.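

In this assay, within the data shown here, the change from phenyl to 4-fluorophenyl gives a 1.6-fold higher number from compound 1 to compound 4 (0.20 log units; within the scatter) and is the first single-place step that can be read. Fluoro is therefore accommodated at this position, para to a large group, without a shift beyond the scatter. Nothing measured here accounts for the size of this step.

On these data alone, whether methoxy, an amine or a carboxylic acid at this position would move the number beyond the scatter remains open. So does whether fluoro would behave alike on the core of compound 3.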